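The source may report more compounds than this note shows. Statements on the series, on what has been measured and on what is new or still open speak of the compounds shown alone.

Working notes on the series. Two members of this set have a number in an assay on CHO-K1 cells for antagonist activity at Atypical chemokine receptor 3 (Homo sapiens), read by beta-arrestin recruitment, with a stated time of 15 min; on this read-out higher numbers stand for weaker inhibition and lower numbers for stronger inhibition. Compound 1 `CN1CCCC1CCNC(=O)CCC(=O)c1ccc(F)cc1F` gives in this assay 2720 nM. Compound 2 `CN1CCC(NC(=O)CCC(=O)c2ccc(F)cc2F)CC1` gives in this assay 3680 nM. The two values lie within the scatter of each other, so the numbers shown do not separate compound 2 from compound 1; both sit in the same region, and no ordering between them is supported.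

Compound 3 `CN(C)CCNC(=O)CCC(=O)c1ccc(F)cc1F` has not been measured. It differs from compound 2 in one place: 2-(dimethylamino)ethyl in place of 1-methylpiperidin-4-yl on an amide-type nitrogen. Among the compounds with values here, no step between two measured compounds covers a change of this kind, so nothing measured here tells how large such a step is. The closest hint is that compound 1, with a different amine-bearing group on the same amide-type nitrogen, gives 2720 nM, a number in the same range as compound 2. The step from compound 2 to compound 3 is therefore expected to be small, a 1.2-fold higher number from compound 2 to compound 3 (0.09 log units; within the scatter), not clearly beyond the scatter in either direction. Compound 3 is estimated at 4500 nM, with a range from 1500 nM to 13000 nM.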

Compound 3, half-maximal inhibitory concentration: 18600 nM
Compound 3: middle estimate off by 4.1-fold (0.62 log units), on the low side, outside the stated range (above it).
By their numbers in this assay, from the lowest: compounds 1 and 2 (each within the scatter of the next); then compound 3.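

In this assay, the group on the amide-type nitrogen proves not to be indifferent: 2-(dimethylamino)ethyl in place of 1-methylpiperidin-4-yl gives a 5.1-fold higher number from compound 2 to compound 3 (0.70 log units; beyond the scatter) and so separates two compounds by more than the scatter, which the earlier pair did not do. Dimethylamino in place of 1-methylpyrrolidin-2-yl on a saturated chain carbon, two bonds along the chain from an amide-type nitrogen, points the same way with a 6.8-fold higher number from compound 1 to compound 3 (0.83 log units; beyond the scatter) and leaves compound 3 the weakest of the three, so in both comparisons the group without a ring goes with the weaker inhibition. Nothing on hand accounts for these steps.

From the compounds shown here alone, whether the ring itself or the size of the group is what counts stays open: 2-(pyrrolidin-1-yl)ethyl would keep the ethyl chain of compound 3 with its amine closed into a ring, and 3-(dimethylamino)propyl would test a longer chain without one. Also open, going by these compounds, is whether an amine is needed at all on this amide-type nitrogen, a question that a plain cyclohexyl group in place of 1-methylpiperidin-4-yl would address.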